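Swapping Sulfur for Selenium in Two Thiocyanate Scaffolds

The source may report more compounds than this note shows. Statements on the series, on what has been measured and on what is new or still open speak of the compounds shown alone.

Of the compounds shown here, three have so far been tested in a functional assay on PC-3 cells (Homo sapiens) for cytotoxicity, read by MTT assay, with a stated time of 72 h; on this read-out lower numbers stand for stronger inhibition of growth and higher numbers for weaker inhibition of growth. Compound 1 `N#CSCN1C(=O)c2ccccc2C1=O` carries a cyanosulfanyl group on a saturated chain carbon bound to an amide-type nitrogen in a ring. For compound 1 this assay reports only a limit, > 100000 nM, and not a number (the limit of > 100000 nM in this assay, at which 1 of the 3 values shown sits). Compound 2 `N#C[Se]CN1C(=O)c2ccccc2C1=O` differs from compound 1 by a group of 3 heavy atoms (1 carbon, 1 nitrogen, 1 selenium; no ring) in place of a group of 3 heavy atoms (1 carbon, 1 nitrogen, 1 sulfur; no ring), on a saturated chain carbon bound to an amide-type nitrogen in a ring, and in this assay compound 2 gives 11200 nM. That change produced an at least 8.9-fold lower number from compound 1 to compound 2 (0.95 log units; beyond the scatter).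

Compound 3 `Cc1noc(C)c1CSC#N` is built on a different core; the difference between the two cores is not broken down here. In this assay compound 3 gives 8000 nM, a value that lies within the usual scatter of the number for compound 2.

Compound 4 `Cc1noc(C)c1C[Se]C#N` has not yet been measured. It differs from compound 3 by a group of 3 heavy atoms (1 carbon, 1 nitrogen, 1 selenium; no ring) in place of a group of 3 heavy atoms (1 carbon, 1 nitrogen, 1 sulfur; no ring), on a saturated chain carbon bound to an aromatic carbon. Among the measured compounds shown here, this is the same kind of change as the one from compound 1 to compound 2, but the place is not the same: here the group sits on a saturated chain carbon bound to an aromatic carbon, whereas before it sat on a saturated chain carbon bound to an amide-type nitrogen in a ring.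

Because the same kind of change gave an at least 8.9-fold lower number from compound 1 to compound 2 (0.95 log units; beyond the scatter), compound 4 is expected to show a lower number than compound 3, with the expected step being a 5.3-fold lower number from compound 3 to compound 4 (0.73 log units; beyond the scatter). That expectation rests on a single measured pair, so the estimate for compound 4 is kept wide: 1500 nM, expected to fall between 400 nM and 6000 nM.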

Compound 4, concentration for 50% growth inhibition: 5600 nM
Estimate against measurement, compound 4: 3.7-fold (0.57 log units) below; low and high end bracket the measured number.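

In this assay, putting selenium in place of sulfur on the saturated chain carbon bound to an aromatic carbon gave a 1.4-fold lower number from compound 3 to compound 4 (0.15 log units; within the scatter), so compound 3 and compound 4 cannot be told apart on this read-out. The swap therefore did not carry over from one core to the other at the size seen first, and the gap between the two results is real rather than an effect of ordinary measurement noise: the same change on two cores in this assay, an at least 8.9-fold lower number (0.95 log units; beyond the scatter) from compound 1 to compound 2 and a 1.4-fold lower number (0.15 log units; within the scatter) from compound 3 to compound 4, at least 6.2-fold (0.79 log units) apart, beyond the scatter of two such steps

What these two pairs do not show is why the cores answer so differently, or how the swap would behave on a third core, and the earlier step rests on compound 1, whose > 100000 nM is a limit and not a number.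

As far as these compounds go, it remains open whether the selenium-for-sulfur swap would matter more or less if a longer chain took the place of the single saturated chain carbon that carries the group on each core. From the compounds shown here alone, it is equally open how an amine or a carboxylic acid added to either core would shift the numbers, and whether the sulfur and selenium partners would then still differ in this assay.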